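This account rests on a few compounds, and the source may have more. Where it says the series, first, only, none or still open, it means among the compounds named here.

Compound 1 `CCCCCCOC(=O)NC(=O)Oc1c(C(C)C)cccc1C(C)C` gives 53 nM in an assay on microsomes from intestine for inhibition of acyl-CoA:cholesterol acyltransferase (Oryctolagus cuniculus); a lower number here means a stronger inhibitor, a higher number a weaker inhibitor. Compound 2 `CC(C)c1cccc(C(C)C)c1OC(=O)NC(=O)SCc1ccc(Cl)cc1` gives 160 nM in this assay.

Of these two numbers compound 2 stands highest; its nearest neighbour is compound 1, and the step of a 3.0-fold higher number from compound 1 to compound 2 (0.48 log units; beyond the scatter) lies beyond the scatter. Compound 3 `CC(C)c1cccc(C(C)C)c1OC(=O)NC(=O)SCCc1ccccc1` differs from compound 2 by benzyl in place of 4-chlorophenyl on a saturated chain carbon bound to a sulfur. Going by the values given here, no measured step bears directly on this change: the one step known, a 3.0-fold higher number from compound 1 to compound 2 (0.48 log units; beyond the scatter), replaces the whole chain on the carbonyl carbon and is modest. For compound 3 the author therefore expects no step beyond the scatter, a 1.1-fold higher number from compound 2 to compound 3 (0.05 log units; within the scatter). Compound 3 is estimated at 180 nM, between 70 nM and 450 nM.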

Compound 3, half-maximal inhibitory concentration: 880 nM
Estimate against measurement, compound 3: 4.9-fold (0.69 log units) below; measured number above the stated range.
By their numbers in this assay, from the lowest: compound 1; then compound 2; then compound 3.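

In this assay, the chain on sulfur proves sensitive to this change: 4-chlorobenzyl to phenethyl is not the neutral swap it might appear, giving a clear loss (a 5.5-fold higher number from compound 2 to compound 3 (0.74 log units; beyond the scatter)). Set against the hexyloxy carbamate, phenethylsulfanyl gives the largest step yet seen (a 17-fold higher number from compound 1 to compound 3 (1.22 log units; beyond the scatter)). Nothing available explains why the phenethyl compound falls so far behind.

From the compounds shown here alone, compound 3 drops the chlorine and lengthens the chain in one change, so which of the two carries the step stays open. A 4-chlorophenethyl or an unsubstituted benzyl on the sulfur would separate them.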